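The source may report more compounds than this note shows. Statements on the series, on what has been measured and on what is new or still open speak of the compounds shown alone.

Measured so far in a functional assay on MDA-MB-231 cells (Homo sapiens) for antiproliferative activity, read by MTT assay, with a stated time of 72 h; a higher number here means a weaker inhibitor, a lower number a stronger inhibitor:
- compound 1 `CC1=CC[C@H]2[C@H](CC[C@]2(C)O)C(C)(C)[C@@H]1CC[C@H]1[C@]2(C)CC[C@H](OC(=O)c3ccncc3)C(C)(C)O[C@H]2CC[C@@]1(C)O`: 18000 nM
- compound 2 `CC1=CC[C@H]2[C@H](CC[C@]2(C)O)C(C)(C)[C@@H]1CC[C@H]1[C@]2(C)CC[C@H](OC(=O)c3cccc([N+](=O)[O-])c3)C(C)(C)O[C@H]2CC[C@@]1(C)O`: 34700 nM

Among the compounds with values here, compound 2, at 34700 nM, cannot be separated from the only other measured compound: the values show a 1.9-fold higher number from compound 1 to compound 2 (0.29 log units; within the scatter), which lies within the scatter.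

The next compound is compound 3 `CC1=CC[C@H]2[C@H](CC[C@]2(C)O)C(C)(C)[C@@H]1CC[C@H]1[C@]2(C)CC[C@H](OC(=O)c3ccccc3F)C(C)(C)O[C@H]2CC[C@@]1(C)O`. The change is 2-fluorophenyl in place of 3-nitrophenyl on a carbonyl carbon. In words, 2-fluorophenyl stands in place of 3-nitrophenyl on a carbonyl carbon, and the shared core stays the same.

Within the data shown here, only one measured step bears on this, the exchange of pyridin-4-yl for 3-nitrophenyl at the same place. That step, a 1.9-fold higher number from compound 1 to compound 2 (0.29 log units; within the scatter), stays within the scatter. Among the measured compounds shown here, it is a single pair, and no measured compound yet carries a fluorine, so the evidence is thin. No step beyond the scatter is therefore expected in this assay, and neither direction is favoured with any confidence.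

The expected step is a 1.2-fold lower number from compound 2 to compound 3 (0.09 log units; within the scatter). For compound 3 the estimated value is 28000 nM, with an expected range of 12000 nM to 60000 nM.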

Compound 3, half-maximal inhibitory concentration: 28700 nM
Estimate against measurement, compound 3: 1.0-fold (0.01 log units) below, within the range that was stated.
By their numbers in this assay, from the lowest: compounds 1, 3 and 2 (each within the scatter of the next).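

In this assay, this place on a carbonyl carbon now holds three aromatic groups, and the new group can be read against both earlier ones: (a 1.2-fold lower number from compound 2 to compound 3 (0.08 log units; within the scatter)) against 3-nitrophenyl and (a 1.6-fold higher number from compound 1 to compound 3 (0.20 log units; within the scatter)) against pyridin-4-yl. Both steps stay within the scatter, so compounds 1, 2 and 3 cannot be separated, and the first fluorine in the series brings no step beyond it. This holds even though the groups differ in their counts: 2-fluorophenyl has 7 heavy atoms and 0 hydrogen-bond acceptors, while 3-nitrophenyl has 9 heavy atoms and 2 hydrogen-bond acceptors. No measurement at hand speaks to what lies behind these values.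

The compounds shown all carry a six-membered aromatic ring at this place, so it remains open whether a ring-free group, such as a longer alkyl chain, or a group bearing an amine or a carboxylic acid would give a step beyond the scatter. Also open, on these data alone, is whether a fluorine elsewhere on the phenyl ring, as in 4-fluorophenyl, would differ from 2-fluorophenyl here.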